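Piperazine aryl change in an oxazole carboxamide series

A few compounds are considered here, and "the series" means these few. Any claim that something is new, unique, unknown or untested is made for them only; others in the source may bear on it.

Measured compounds in a functional assay on HL-60 cells (Homo sapiens) for inhibition, read by MTT assay, with a stated time of 72 h; on this read-out lower numbers stand for stronger inhibition and higher numbers for weaker inhibition:
compound 1 `Cc1nc(-c2ccccc2)c(C(=O)N2CCN(c3cccc(Cl)c3Cl)CC2)o1`: 133 nM
compound 2 `Cc1nc(-c2ccccc2F)c(C(=O)N2CCN(c3cc(Cl)cc(Cl)c3)CC2)o1`: 60.2 nM
compound 3 `Cc1nc(-c2ccccc2Cl)c(C(=O)N2CCN(c3cccc(Cl)c3)CC2)o1`: 132 nM

Compound 1 holds the highest of the three numbers in this assay; compound 3 sits within the scatter of it, while compound 2 lies beyond the scatter below it. The change toward compound 4 `Cc1nc(-c2ccccc2)c(C(=O)N2CCN(c3ccc(F)cc3)CC2)o1` is 4-fluorophenyl in place of 2,3-dichlorophenyl on an amine nitrogen in a ring. For the measured compounds named here, no measured pair shows this change directly, so the expectation rests on the three numbers alone, where the compounds carrying chlorine-bearing aryl groups give the lower numbers. The step from compound 1 is expected to be modest and toward a weaker inhibition, a 2.3-fold higher number from compound 1 to compound 4 (0.35 log units; beyond the scatter). Compound 4 is therefore estimated at 300 nM, with a range from 100 nM to 1000 nM.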

Compound 4, half-maximal inhibitory concentration: > 1000 nM
Compound 4 ended at the assay's limit; the forecaster's own chance of this, stated with the estimate: 5%; middle value at least 3.3-fold (0.52 log units) from the limit.
By their numbers in this assay, from the lowest: compound 2; then compounds 3 and 1 (each within the scatter of the next). At a limit, above all of these: compound 4.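

In this assay, the position on an amine nitrogen in a ring now has its first direct reading: 4-fluorophenyl in place of 2,3-dichlorophenyl gives an at least 7.5-fold higher number from compound 1 to compound 4 (0.87 log units; beyond the scatter). On the core of compound 1, inhibition at this position therefore depends strongly on the aryl group, and the step has only a lower bound. The result for compound 4 is a limit and not a number: the limit of > 1000 nM in this assay, at which 1 of the 4 values shown sits.

Open, going by these compounds, is how 4-chlorophenyl or plain phenyl would read at this position. Those two groups would separate the change of halogen from the change in where it sits on the ring.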